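The source may report more compounds than this note shows. Statements on the series, on what has been measured and on what is new or still open speak of the compounds shown alone.

Compound 1 `NC(=O)c1sc2nc(Cc3ccccc3)cc(C(F)(F)F)c2c1N` and compound 2 `Cc1ccc(-c2cc(C(F)(F)F)c3c(N)c(C(N)=O)sc3n2)o1` share one core and differ only in the group attached to an aromatic carbon. In an assay on isolated protein for inhibition of LIM domain kinase 1 (Homo sapiens), read by Kinase-Glo, with a stated time of 60 min (on this read-out lower numbers stand for stronger inhibition and higher numbers for weaker inhibition), compound 1 gives 30000 nM, and compound 2 gives 41000 nM. Compound 2 stands at the higher end of these two numbers, although the gap to compound 1 lies within the scatter. Going by the values given here, the single measured step, a 1.4-fold higher number from compound 1 to compound 2 (0.14 log units; within the scatter), shows that exchanging a benzyl for a 5-methylfuran-2-yl at this place changed little. Compound 3 `NC(=O)c1sc2nc(-c3cccs3)cc(C(F)(F)F)c2c1N` carries the change (thiophen-2-yl in place of 5-methylfuran-2-yl on an aromatic carbon), again an exchange of one small aromatic group for another at the same place. Because the earlier exchange gave a 1.4-fold higher number from compound 1 to compound 2 (0.14 log units; within the scatter), a similar outcome is expected, so the estimated step of a 1.0-fold lower number from compound 2 to compound 3 (0.01 log units; within the scatter) should stay within the scatter. Compound 3 is therefore expected to give about 40000 nM, with a likely range from 15000 nM to 100000 nM.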

Compound 3, half-maximal inhibitory concentration: 1600 nM
For compound 3 the middle estimate is 25-fold (1.40 log units) above the measured one, outside the stated range (below it).
By their numbers in this assay, from the lowest: compound 3; then compounds 1 and 2 (each within the scatter of the next).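

In this assay, thiophen-2-yl in place of 5-methylfuran-2-yl gives a 26-fold lower number from compound 2 to compound 3 (1.41 log units; beyond the scatter), and thiophen-2-yl in place of benzyl gives a 19-fold lower number from compound 1 to compound 3 (1.27 log units; beyond the scatter). This position therefore does respond to the group it carries, although benzyl and 5-methylfuran-2-yl alone gave no sign of that, and even though thiophen-2-yl and 5-methylfuran-2-yl are both five-membered aromatic rings with one hetero atom and the same counts of donors and acceptors. No measurement at hand bears on why the number falls so far.

Two things change together between compound 2 and compound 3, the ring oxygen becoming sulfur and the methyl going, so the compounds shown leave open which of them matters. As far as these compounds go, whether an unsubstituted furan-2-yl or a 5-methylthiophen-2-yl would separate the two, and whether a phenyl or an amine here would keep the lower number, also remains open.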